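The source may hold more compounds than are shown below. What is called first, only, known or untested is meant among the compounds shown, and "the series" means these compounds.

Compound 1 `COc1ccccc1-c1cccc(S(=O)(=O)N2CCC(N3CCC(C)CC3)CC2)c1` carries a 2-methoxyphenyl group on the shared core. In an ADME assay on HCT-116 cells (Homo sapiens) for cytotoxicity, read by CellTiter-Glo, with a stated time of 72 h (a lower number here means a stronger inhibitor, a higher number a weaker inhibitor), compound 1 gives > 5000 nM, which is a limit of the assay rather than a number. Compound 2 `CC1CCN(C2CCN(S(=O)(=O)c3ccc(Br)cc3OC(F)(F)F)CC2)CC1` was run in the same assay. In this assay compound 2 gives > 5000 nM, again a limit. What the numbers show is summarised as the limit of > 5000 nM in this assay, at which 2 of the 2 values shown sit. Among the compounds with values here, compound 1 thus stands at the assay limit, and the one further value shown is also only a limit, so no step between measured compounds can be read off. Compound 3 `COc1cccc(S(=O)(=O)N2CCC(N3CCC(C)CC3)CC2)c1` differs from compound 1 by methoxy in place of 2-methoxyphenyl on an aromatic carbon. Within the data shown here, with no measured step of any kind available, the expected step from compound 1 to compound 3 is none beyond the usual scatter, most likely with the read-out staying at the limit. The estimate for compound 3 is 8000 nM, in the range 3000 nM to 30000 nM, which corresponds to an expected step that the limit leaves unreadable from compound 1 to compound 3.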

Compound 3, half-maximal inhibitory concentration: > 5000 nM
Compound 3: a limit, no number; the forecaster's own chance of this, stated with the estimate: 80%; the middle value does not contradict the limit.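

In this assay, within the data shown here, compound 3 gives > 5000 nM, again a limit, and compound 1 also stands at a limit, so no step between compound 1 and compound 3 can be read. The compounds shown leave open whether any change on the shared core shifts this read-out: the limit of > 5000 nM in this assay, at which 3 of the 3 values shown sit.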